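This account rests on a few compounds, and the source may have more. Where it says the series, first, only, none or still open, it means among the compounds named here.

Compound 3 `Oc1cccc(-c2cc(-c3ccc(Cl)cc3)nc(-c3ccco3)c2)c1` gives 8190 nM in an ADME assay on HEK293 cells (Homo sapiens) for cytotoxicity, read by CCK-8 assay and cell counting, with a stated time of 2 days (a lower number here means a stronger inhibitor, a higher number a weaker inhibitor), and stands at the upper end of the three numbers measured: compound 1 `Oc1ccc(-c2cc(-c3ccco3)nc(-c3ccccc3Cl)c2)cc1` gives 4310 nM, within the scatter of it, while compound 2 `Oc1cccc(-c2cc(-c3cccc(Cl)c3)nc(-c3ccco3)c2)c1` gives 2530 nM, the step of a 3.2-fold higher number from compound 2 to compound 3 (0.51 log units; beyond the scatter) lying beyond the scatter. Compound 4 `Oc1cccc(-c2cc(-c3ccco3)nc(-c3ccccc3Cl)c2)c1` differs from compound 3 by 2-chlorophenyl in place of 4-chlorophenyl on an aromatic carbon. Among the compounds with values here, no measured step covers this exact change. Within the data shown here, the only step that bears on it is a 3.2-fold higher number from compound 2 to compound 3 (0.51 log units; beyond the scatter), modest in size. Compound 1 also carries a 2-chlorophenyl group but differs from compound 4 in a second place as well; in this assay compound 1 gives 4310 nM. A moderate lowering is therefore expected for compound 4, roughly a 2.0-fold lower number from compound 3 to compound 4 (0.31 log units; beyond the scatter). Compound 4 is estimated at 4000 nM, with a range from 1500 nM to 11000 nM.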

Compound 4, half-maximal inhibitory concentration: 1860 nM
Compound 4: middle estimate off by 2.2-fold (0.33 log units), on the high side, and the stated range covers the measured number.
By their numbers in this assay, from the lowest: compounds 4, 2, 1 and 3 (each within the scatter of the next, the first and the last beyond it).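

In this assay, the 2-chlorophenyl group separates from the 4-chlorophenyl group with a 4.4-fold lower number from compound 3 to compound 4 (0.64 log units; beyond the scatter) and does not separate from the 3-chlorophenyl group with a 1.4-fold lower number from compound 2 to compound 4 (0.13 log units; within the scatter), so among these three only the 4-chlorophenyl compound stands apart. With 2-chlorophenyl held fixed, the hydroxyl placement also counts, as 3-hydroxyphenyl in place of 4-hydroxyphenyl gives a 2.3-fold lower number from compound 1 to compound 4 (0.36 log units; beyond the scatter). No supporting evidence accounts for either shift. The compounds shown leave open how an amine or a methoxy group in place of the hydroxyl would read here. They also leave open whether a fluorine in place of the chlorine would preserve these steps.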